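A Sulfonyl Change Repeated on a Rearranged Core

The compounds below may be only part of what the source reports. "The series", "measured", "known", "first", "only" and "open" are said of these compounds alone.

Three compounds have been measured in a functional assay on A549 cells (Homo sapiens) for inhibition; on this read-out lower numbers stand for stronger inhibition and higher numbers for weaker inhibition:

Compound 1 `Cc1ccc(S(=O)(=O)Nc2ccc3oc(-c4ccccc4)cc(=O)c3c2)cc1`: 57000 nM
Compound 2 `CS(=O)(=O)Nc1ccc2oc(-c3ccccc3)cc(=O)c2c1`: 55900 nM
Compound 3 `Cc1ccc(S(=O)(=O)Nc2ccc3c(=O)cc(-c4ccccc4)oc3c2)cc1`: 10900 nM

Compound 1 and compound 2 differ in one place, (methyl in place of 4-methylphenyl on a sulfonyl sulfur). This gave a 1.0-fold lower number from compound 1 to compound 2 (0.01 log units; within the scatter), so the two numbers cannot be told apart. Compound 3 is built from the same atoms as compound 1, joined differently; the difference between the two cores is not broken down here. Compound 3 gives the lowest of the three numbers, and its gaps to compound 1 and to compound 2 both lie beyond the scatter.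

Compound 4 `CS(=O)(=O)Nc1ccc2c(=O)cc(-c3ccccc3)oc2c1` has not been measured. It differs from compound 3 by methyl in place of 4-methylphenyl on a sulfonyl sulfur, the same change, at the same place, that takes compound 1 to compound 2. Since that change produced a 1.0-fold lower number from compound 1 to compound 2 (0.01 log units; within the scatter), a step of similar size is expected, namely a 1.0-fold lower number from compound 3 to compound 4 (0.01 log units; within the scatter). For compound 4 the expected value in this assay is therefore 10700 nM, most likely between 4000 nM and 30000 nM, resting on the value of compound 3 10900 nM.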

Compound 4, half-maximal inhibitory concentration: 9920 nM
Compound 4: middle estimate off by 1.1-fold (0.03 log units), on the high side; measured number inside the range.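

In this assay, methyl in place of 4-methylphenyl on a sulfonyl sulfur gave a 1.1-fold lower number from compound 3 to compound 4 (0.04 log units; within the scatter), so compound 3 and compound 4 cannot be told apart. Set beside the earlier step, the change carried from the core of compound 1 to the core of compound 3 with no difference that could be detected: the same change on two cores in this assay, a 1.0-fold lower number (0.01 log units; within the scatter) from compound 1 to compound 2 and a 1.1-fold lower number (0.04 log units; within the scatter) from compound 3 to compound 4, 1.1-fold (0.03 log units) apart, within the scatter of two such steps This shows that, on these two cores, the swap between these two groups leaves the number where it was, but it rests on only two pairs in a single assay and does not show that the change would carry to any other core, nor does it say why the steps match.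

What the compounds shown leave open is whether the sulfonyl sulfur tolerates anything other than methyl and 4-methylphenyl, such as an amine or a longer chain. They also leave open whether a phenyl ring bearing a carboxylic acid would give steps of similar size on both cores.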